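Aryl amine swap on the shared core

The source may report more compounds than this note shows. Statements on the series, on what has been measured and on what is new or still open speak of the compounds shown alone.

Within the data shown here, compound 1 `O=C1C(Nc2ccccc2F)=CC(=O)c2c1nc1n2[C@H]2OC[C@@H](O)[C@H]2OC1` is the anchor: in a functional assay on MGC-803 cells (Homo sapiens) for inhibition, read by sulforhodamine B assay (a higher number here means a weaker inhibitor, a lower number a stronger inhibitor), compound 1 gives 2000 nM, the only plain number in hand. Compound 2 `O=C1C=C(NC2CCCC2)C(=O)c2c1nc1n2[C@H]2OC[C@@H](O)[C@H]2OC1` in this assay gives > 8000 nM, a limit rather than a number (the limit of > 8000 nM in this assay, at which 1 of the 2 values shown sits). Compound 3 `O=C1C(Nc2ccc(C(F)(F)F)cc2)=CC(=O)c2c1nc1n2[C@H]2OC[C@@H](O)[C@H]2OC1` changes compound 1 by 4-(trifluoromethyl)phenyl in place of 2-fluorophenyl on an amine nitrogen. Among the measured compounds shown here, no measured step separates the compounds, so the step from compound 1 to compound 3 is expected to be small, at most a modest weakening, a 1.5-fold higher number from compound 1 to compound 3 (0.18 log units; within the scatter). Compound 3 is estimated at 3000 nM in this assay, within 1000 nM to 9000 nM.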

Compound 3, half-maximal inhibitory concentration: 1860 nM
The estimate for compound 3 lay 1.6-fold (0.21 log units) above the measured number; the measured number falls inside the stated range.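

Among these compounds, on the amine nitrogen of the shared core, 4-(trifluoromethyl)phenyl in place of 2-fluorophenyl gives a 1.1-fold lower number from compound 1 to compound 3 (0.03 log units; within the scatter) in this assay, the first step that can be read. This position therefore holds either aryl group with no change beyond the scatter, despite the different fluorine substitution. No measured property shown bears on this result.

Among the compounds shown here, compound 2 gives > 8000 nM, a limit and not a number, and no step to it can be read. Still open, from the compounds shown here alone, is whether a pyridine ring, a carboxylic acid on the phenyl ring or a longer alkyl chain on this nitrogen would move the number beyond the scatter.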